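Moving a methyl group around the piperazine aryl ring

This account rests on a few compounds, and the source may have more. Where it says the series, first, only, none or still open, it means among the compounds named here.

Three compounds share one core. Compound 1 `Cc1ccccc1N1CCN(CCCCOc2ccc3c(=O)cc(-c4ccccc4)oc3c2)CC1` gives 19.5 nM in a functional assay for antagonist activity at Adrenergic receptor alpha-1 (Rattus norvegicus); on this read-out lower numbers stand for tighter binding and higher numbers for weaker binding. Compound 2 `O=c1cc(-c2ccc(Cl)cc2)oc2cc(OCCCCN3CCN(c4ccccc4)CC3)ccc12` gives 12.2 nM, and compound 3 `Cc1ccc(N2CCN(CCCCOc3ccc4c(=O)cc(-c5ccc(Cl)cc5)oc4c3)CC2)cc1` gives 3.18 nM, the lowest of the three numbers. For the measured compounds named here, the one single-point step here, a 3.8-fold lower number from compound 2 to compound 3 (0.58 log units; beyond the scatter), shows what adding the methyl did. Compound 4 `Cc1ccccc1N1CCN(CCCCOc2ccc3c(=O)cc(-c4ccc(Cl)cc4)oc3c2)CC1` differs from compound 3 by 2-methylphenyl in place of 4-methylphenyl on an amine nitrogen in a ring. Going by the values given here, no measured pair isolates this shift of the methyl group; compound 1 also carries 2-methylphenyl but differs from compound 4 in a second place too, so the value of compound 1, 19.5 nM, is only a loose pointer. The expectation for compound 4 is therefore a small rise of about a 2.5-fold higher number from compound 3 to compound 4 (0.40 log units; beyond the scatter), giving an estimated 8 nM with a range from 2.5 nM to 25 nM.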

Compound 4, dissociation constant: 33.8 nM
Compound 4: middle estimate off by 4.2-fold (0.63 log units), on the low side; the measured number lies above the stated range.
By their numbers in this assay, from the lowest: compound 3; then compounds 2, 1 and 4 (each within the scatter of the next, the first and the last beyond it).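

Where the methyl sits on the phenyl ring carried by the amine nitrogen matters greatly: swapping 4-methylphenyl for 2-methylphenyl gives an 11-fold higher number from compound 3 to compound 4 (1.03 log units; beyond the scatter) and undoes the gain seen with the 4-methylphenyl group. Against the unsubstituted phenyl compound, the 2-methylphenyl group goes the other way, with a 2.8-fold higher number from compound 2 to compound 4 (0.44 log units; beyond the scatter) and a modest loss. With 2-methylphenyl in place, chloro on the other aryl ring gives a 1.7-fold higher number from compound 1 to compound 4 (0.24 log units; within the scatter) and no clear change. Nothing available explains why the position matters so much. Going by these compounds, whether a methoxy group in place of the methyl would show the same dependence on position remains open.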